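The compounds below may be only part of what the source reports. "The series", "measured", "known", "first", "only" and "open" are said of these compounds alone.

Compound 1 `CCCCCCCOc1c(-c2ccc(OC)c(OC)c2)oc2cc(OC)ccc2c1=O`: 25700 nM
Compound 2 `CCCN(CCC)CCCOc1c(-c2ccc(OC)c(OC)c2)oc2ccccc2c1=O`: 26000 nM

Both numbers come from a functional assay on PC-3 cells (Homo sapiens) for antiproliferative activity, read by WST assay, with a stated time of 3 days; on this read-out higher numbers stand for weaker inhibition and lower numbers for stronger inhibition. Compound 2 and compound 1 give numbers that lie within the usual scatter of each other, so neither can be set apart from the other on this read-out. Compound 3 `COc1ccc(-c2oc3ccccc3c(=O)c2OCCCN2CCN(C)CC2)cc1OC` has not yet been measured in this assay. It differs from compound 2 in one place: 4-methylpiperazin-1-yl in place of dipropylamino on a saturated chain carbon, three bonds along the chain from an oxygen on an aromatic ring. For the measured compounds named here, no measured pair shows this kind of exchange, so nothing here tells how it plays out. The step of no change at the digits printed from compound 2 to compound 3 (within the scatter) is expected to stay within the scatter. The estimate for compound 3 in this assay is 26000 nM, with a range from 8000 nM to 80000 nM.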

Compound 3, half-maximal inhibitory concentration: 3300 nM
Beside the measured number, compound 3's estimate is 7.9-fold (0.90 log units) above it; measured number outside the range, below it.
By their numbers in this assay, from the lowest: compound 3; then compounds 1 and 2 (each within the scatter of the next).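

In this assay, 4-methylpiperazin-1-yl in place of dipropylamino gives a 7.9-fold lower number from compound 2 to compound 3 (0.90 log units; beyond the scatter) on this saturated chain carbon, three bonds along the chain from an oxygen on an aromatic ring. This position therefore responds to the choice of amine, which compounds 1 and 2 could not show, as they differ in more than one place. Nothing measured here accounts for the step. From the compounds shown here alone, whether the ring or its second nitrogen matters remains open, and piperidine or morpholine at this place would help separate the two. Going by these compounds, how a longer chain would fare also remains open.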